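Chloro in Place of Methoxy on Compound 2

A few compounds are considered here, and "the series" means these few. Any claim that something is new, unique, unknown or untested is made for them only; others in the source may bear on it.

Compound 2 `COc1ccc(-c2nc(C)c(C(=O)CSc3nc(-c4ccc(OC)cc4)c(C#N)c(=O)[nH]3)s2)cc1` is the compound followed here. In a functional assay on U-87MG ATCC cells for antiproliferative activity against U-87 MG (Homo sapiens), read by MTT assay, with a stated time of 48 h (a higher number here means a weaker inhibitor, a lower number a stronger inhibitor), compound 2 gives 25300 nM, the lowest of the three numbers shown, with the other two inside the scatter of it: compound 1 `COc1ccc(-c2nc(SCC(=O)c3sc(-c4ccccc4)nc3C)[nH]c(=O)c2C#N)cc1` gives 48400 nM in this assay, and compound 3 `COc1cccc(-c2nc(SCC(=O)c3sc(-c4ccc(Cl)cc4)nc3C)[nH]c(=O)c2C#N)c1` gives 41000 nM. Among the measured compounds shown here, the one single-change step among them, a 1.9-fold lower number from compound 1 to compound 2 (0.28 log units; within the scatter), stays within the scatter. Compound 4 `COc1ccc(-c2nc(C)c(C(=O)CSc3nc(-c4ccc(Cl)cc4)c(C#N)c(=O)[nH]3)s2)cc1` differs from compound 2 by chloro in place of methoxy on an aromatic carbon. For the measured compounds named here, no measured step bears directly on this change: the step from compound 1 to compound 2 concerns a different part of the shared core, and compound 3 differs from compound 2 in two places, so its value shows only that a chloro-bearing analogue sits near compound 2. Going by the values given here, with no step in the set running beyond the scatter in either direction, compound 4 is expected to stay close to compound 2, a 1.2-fold higher number from compound 2 to compound 4 (0.07 log units; within the scatter). The estimate for compound 4 in this assay is 30000 nM, with a range from 12000 nM to 75000 nM.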

Compound 4, half-maximal inhibitory concentration: 45900 nM
Compound 4: the middle estimate sits 1.5-fold (0.18 log units) below what was measured; the range from low to high includes it.
By their numbers in this assay, from the lowest: compounds 2, 3, 4 and 1 (each within the scatter of the next).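

In this assay, the step from 4-methoxyphenyl to 4-chlorophenyl, para to a large group, gives a 1.8-fold higher number from compound 2 to compound 4 (0.26 log units; within the scatter), so this first direct test of the position shows no separation between the two compounds. Methoxy, with its two heavy atoms and one hydrogen-bond acceptor, and chloro, with one heavy atom and no acceptor, therefore cannot be told apart here, while the second methoxy of compound 2 stays in place in compound 4. The data give no explanation for this result. Going by these compounds, whether an amine or a carboxylic acid at this position would take the number beyond the scatter remains open. So does the outcome of a longer chain there, and of the same exchange at the remaining methoxy of compound 4.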